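Aryl series notes: from compound 3 to compound 4

This account rests on a few compounds, and the source may have more. Where it says the series, first, only, none or still open, it means among the compounds named here.

In a functional assay on RT-112 cells (Homo sapiens) for antiproliferative activity, read by MTT assay, with a stated time of 72 h (a lower number here means a stronger inhibitor of growth, a higher number a weaker inhibitor of growth), compound 3 `COc1cc(Nc2ncnc3c(NC(=O)Nc4ccc(Cl)cc4)cccc23)cc(OC)c1` gives 2490 nM, the higher of the two numeric values, while compound 1 `COc1cc(Nc2ncnc3c(NC(=O)Nc4cc(Cl)cc(Cl)c4)cccc23)cc(OC)c1` gives 30.2 nM. That gap is an 82-fold higher number from compound 1 to compound 3 (1.92 log units; beyond the scatter). Compound 2 `COc1cc(Nc2ncnc3c(NC(=O)Nc4ccc(Cl)c(C(F)(F)F)c4)cccc23)cc(OC)c1` reads > 20000 nM, which is a limit of the assay and not a number. Compound 4 `COc1cc(Nc2ncnc3c(NC(=O)Nc4ccc(C(F)(F)F)cc4)cccc23)cc(OC)c1` differs from compound 3 by trifluoromethyl in place of chloro on an aromatic carbon, para to a large group. Within the data shown here, no measured step makes this exact exchange. The closest is an at least 8.0-fold lower number from compound 2 to compound 3 (0.90 log units; beyond the scatter), where hydrogen replaces trifluoromethyl, and an at least 660-fold higher number from compound 1 to compound 2 (2.82 log units; beyond the scatter) also points towards weaker growth inhibition with trifluoromethyl present. A modest rise is therefore expected, an estimated 2.4-fold higher number from compound 3 to compound 4 (0.38 log units; beyond the scatter). Compound 4 is estimated at 6000 nM, with an expected range of 1500 nM to 20000 nM.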

Compound 4, concentration for 50% growth inhibition: 3920 nM
Estimate against measurement, compound 4: 1.5-fold (0.18 log units) above; the measured number falls inside the stated range.
By their numbers in this assay, from the lowest: compound 1; then compounds 3 and 4 (each within the scatter of the next). At a limit, above all of these: compound 2.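

In this assay, trifluoromethyl and chloro para to a large group cannot be told apart (a 1.6-fold higher number from compound 3 to compound 4 (0.20 log units; within the scatter)), and neither group at this position closes the gap to 3,5-dichlorophenyl (a 130-fold higher number from compound 1 to compound 4 (2.11 log units; beyond the scatter)). The 4-(trifluoromethyl)phenyl group also reads lower than 4-chloro-3-(trifluoromethyl)phenyl (an at least 5.1-fold lower number from compound 2 to compound 4 (0.70 log units; beyond the scatter)). For compound 2 that comparison rests on a limit, not a number: the limit of > 20000 nM in this assay, at which 1 of the 4 values shown sits.

Still open, on these data alone, is whether an amine or a carboxylic acid at this position would separate from chloro and trifluoromethyl. Also open, as far as these compounds go, is whether any single group here can come near 3,5-dichlorophenyl.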